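A few compounds are considered here, and "the series" means these few. Any claim that something is new, unique, unknown or untested is made for them only; others in the source may bear on it.

Measured so far in a functional assay on RAW264.7 cells (Mus musculus) for inhibition, read by microscopy and resazurin assay, with a stated time of 72 h; a lower number here means a stronger inhibitor, a higher number a weaker inhibitor:
compound 1 `C=CCONC(=O)Cn1cc(C(=O)NCC(=O)N[C@H](C(=O)O)C(C)C)c2ccccc21` gives > 128000 nM, which is a limit of this assay.
compound 2 `C=CCONC(=O)Cn1cc(C(=O)NCC(=O)N[C@@H](CC(C)C)C(=O)O)c2ccccc21` gives > 128000 nM, also a limit of this assay.
compound 3 `C=CCONC(=O)Cn1cc(C(=O)N[C@@H](C)C(=O)N[C@H](C(=O)O)C(C)C)c2ccccc21` gives > 128000 nM, also a limit of this assay.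

Compound 3 thus stands at the limit, and the two further values shown are limits as well, so no order among the three can be read. Compound 4 `C=CCONC(=O)Cn1cc(C(=O)N[C@@H](C)C(=O)N[C@@H](CC(C)C)C(=O)O)c2ccccc21` has not yet been measured. It differs from compound 3 in one place: isobutyl in place of isopropyl on a saturated chain carbon bound to an amide-type nitrogen and a carbonyl carbon. The same change has already been tried once in the series, as the step that the two limits leave unreadable from compound 1 to compound 2, and the step that the two limits leave unreadable from compound 1 to compound 3 covers the other point at which compound 3 differs from compound 1. Neither step is readable because of the limit of > 128000 nM in this assay, at which 3 of the 3 values shown sit. Going by the values given here, no measured step therefore gives a size or a direction for the change from compound 3 to compound 4; what the three values show is only that every member tried so far sits at the limit. The expectation for compound 4 is a further limit, with the step that the limit leaves unreadable from compound 3 to compound 4 expected to remain unreadable. The estimate for compound 4 is 200000 nM, in the range 100000 nM to 1000000 nM, most likely reported only as a limit.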

Compound 4, half-maximal inhibitory concentration: > 128000 nM
Compound 4: no number, only a limit; the forecaster's own chance of this, stated with the estimate: 85%; the middle value lies beyond the limit too.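

Compound 4 gives > 128000 nM, a limit of this assay. No new step can be read from compound 4 to compound 3 or compound 2, because the values offer no number to compare: the limit of > 128000 nM in this assay, at which 4 of the 4 values shown sit.

The compounds shown leave open the size and direction of both changes, isobutyl in place of isopropyl and methyl in place of hydrogen.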